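The compounds below may be only part of what the source reports. "The series", "measured", "known", "first", "only" and "open" are said of these compounds alone.

Measured in a functional assay on RAW264.7 cells (Mus musculus) for inhibition, with stated times of 2 h and 24 h; a lower number here means a stronger inhibitor, a higher number a weaker inhibitor:
- compound 1 `COc1ccc(CSC2c3cc(OC)cc(OC)c3[C@@H](c3ccc(OC)cc3)[C@@H]2c2cc(OC)cc(OC)c2)cc1`: 12500 nM
- compound 2 `COc1ccc([C@@H]2c3c(OC)cc(OC)cc3C(SCc3ccc(F)cc3)[C@H]2c2cc(OC)cc(OC)c2)cc1`: > 200000 nM (a limit, not a number)

Compound 2 stands at the limit of > 200000 nM in this assay, at which 1 of the 2 values shown sits, so its true number is not known. Compound 3 `COc1ccc([C@@H]2c3c(OC)cc(OC)cc3C(SCc3ccc(Cl)cc3)[C@H]2c2cc(OC)cc(OC)c2)cc1` differs from it in one place: chloro in place of fluoro on an aromatic carbon, para to a large group (chloro in place of fluoro on an aromatic carbon). Among the measured compounds shown here, one measured step bears on this change, the one in which that fluoro entered in place of methoxy: an at least 16-fold higher number from compound 1 to compound 2 (1.20 log units; beyond the scatter). That step is large and beyond the scatter, so this group can matter greatly in this assay. Chloro itself has not been measured here, so the direction is uncertain. A modest move towards a lower number is expected, and an at least 2.5-fold lower number from compound 2 to compound 3 (0.39 log units; beyond the scatter) is the estimated step. Compound 3 is expected to stay a weak inhibitor, at an estimated 80000 nM, with an expected range of 15000 nM to 250000 nM.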

Compound 3, half-maximal inhibitory concentration: > 200000 nM
Compound 3: no number, only a limit; the forecaster's own chance of this, stated with the estimate: 45%; at least 2.5-fold (0.39 log units) between middle value and limit.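

In this assay, chloro in place of methoxy on the aromatic carbon gives an at least 16-fold higher number from compound 1 to compound 3 (1.20 log units; beyond the scatter), so the large change seen with fluoro also appears with a second halogen and is not confined to fluoro. Compound 3 gives > 200000 nM, which is a limit and not a number. The steps between compound 2 and compound 3 cannot be read, so these two halogens cannot be ranked against each other, and most of the results now sit at one end of the scale: the limit of > 200000 nM in this assay, at which 2 of the 3 values shown sit.

On these data alone, whether an amine or a hydroxyl on this aromatic carbon would give a readable number remains open. Also open, as far as these compounds go, is how weak compound 2 and compound 3 truly are.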